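The source may hold more compounds than are shown below. What is called first, only, known or untested is meant among the compounds shown, and "the series" means these compounds.

Working notes on the series in a functional assay on NCI-H460 cells (Homo sapiens) for cytotoxicity, read by MTT assay; a lower number here means a stronger inhibitor, a higher number a weaker inhibitor. Compound 1 `CCc1cc(S(=O)(=O)N2C[C@H](c3ccccc3)NC2=O)ccc1NC(=O)c1ccc(N)cc1` gives 670 nM in this assay, the lowest of the two numbers reported. Compound 2 `CCOC(=O)Nc1ccc(S(=O)(=O)N2C(=O)N[C@@H](c3ccccc3)C2C)cc1Cl` gives 6000 nM, a gap from compound 1 that lies beyond the scatter. Compound 3 `Cc1cc(S(=O)(=O)N2C(=O)N[C@@H](c3ccccc3)C2C)ccc1NC(=O)c1ccc([N+](=O)[O-])cc1` gives > 10000 nM, which is a limit of this assay and not a number; this is the limit of > 10000 nM in this assay, at which 1 of the 3 values shown sits. Compound 4 `CCc1cc(S(=O)(=O)N2C[C@H](c3ccccc3)NC2=O)ccc1NC(=O)NC1CCCCC1` is not yet measured; it departs from compound 1 by cyclohexylamino in place of 4-aminophenyl on a carbonyl carbon. For the measured compounds named here, no step between measured compounds bears on this change, so the expectation rests on the standing of compound 1 alone. The expected step is a 3.0-fold higher number from compound 1 to compound 4 (0.47 log units; beyond the scatter), a weakening of modest size. Compound 4 is expected to give 2000 nM, within 600 nM to 8000 nM.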

Compound 4, half-maximal inhibitory concentration: 300 nM
Estimate against measurement, compound 4: 6.7-fold (0.82 log units) above; measured number below the stated range.
By their numbers in this assay, from the lowest: compound 4; then compound 1; then compound 2. At a limit, above all of these: compound 3.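

In this assay, for the compounds shown here, cyclohexylamino in place of 4-aminophenyl on a carbonyl carbon gives a 2.2-fold lower number from compound 1 to compound 4 (0.35 log units; beyond the scatter) and provides the first step at this position. An aromatic ring on this carbonyl carbon is therefore not needed for a low number on the core of compound 1, and the non-aromatic ring does better here. No measurement shown gives a cause for this step.

From the compounds shown here alone, the change alters the ring and the atom joining it to the carbonyl carbon together, so their separate contributions remain open. Phenylamino at the same place would separate the two.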